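Mirror Image of a Lactone Acid in a Growth Assay

The compounds below may be only part of what the source reports. "The series", "measured", "known", "first", "only" and "open" are said of these compounds alone.

Compound 2 `CC1(C)[C@@H]2CC3=N[C@@H](CCC(=O)O)C(=O)O[C@@]3(C)[C@H]1C2` carries a carboxymethyl group on a saturated chain attached to the shared core. In an ADME assay on MCF-10A cells (Homo sapiens) for antiproliferative activity, read by sulforhodamine B assay, with a stated time of 48 h (a higher number here means a weaker inhibitor, a lower number a stronger inhibitor), compound 2 reaches only the limit > 1200000 nM, not a number. Compound 1 `C[C@H]1N=C2C[C@H]3C[C@H](C3(C)C)[C@@]2(C)OC1=O` also stops at a limit, > 1800000 nM. Compound 3 `C[C@@H]1N=C2C[C@@H]3C[C@@H](C3(C)C)[C@]2(C)OC1=O` likewise gives the limit > 2000000 nM. Compounds 1 and 3 are mirror images (the fact that compounds 1 and 3 differ only in the configuration as drawn), yet the step that the two limits leave unreadable from compound 1 to compound 3 and the step that the two limits leave unreadable from compound 2 to compound 3 cannot be read in size. Compound 4 `CC1(C)[C@H]2CC3=N[C@H](CCC(=O)O)C(=O)O[C@]3(C)[C@@H]1C2` differs from compound 2 only in configuration: the two compounds have the same atoms and bonds and differ only in configuration as drawn: 4 of 4 stereo elements differ (all stereocentres are inverted: mirror images); a stereocentre at a saturated ring carbon is drawn S in compound 2 and R in compound 4; a stereocentre at a saturated ring carbon is drawn S in compound 2 and R in compound 4; a stereocentre at a saturated ring carbon is drawn S in compound 2 and R in compound 4; a stereocentre at a saturated ring carbon is drawn S in compound 2 and R in compound 4. Because the limit of > 1800000 nM in this assay, at which 1 of the 3 values shown sits, and the limit of > 2000000 nM in this assay, at which 1 of the 3 values shown sits, hold both partners of the mirror pair, compound 4 is expected to stay near a limit too, a step that the limit leaves unreadable from compound 2 to compound 4 of no readable size. The estimate for compound 4 is 1500000 nM, between 300000 nM and 5000000 nM.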

Compound 4, half-maximal inhibitory concentration: > 1200000 nM
Compound 4 was reported as a limit (the forecaster's own chance of this, stated with the estimate: 85%); the middle value does not contradict the limit.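

Compound 4, like compound 2, ends at a limit, so neither the step between these mirror images nor the step from compound 1 to compound 4 can be read. The compounds shown leave open whether configuration or the carboxymethyl group changes potency at all.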